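The compounds below may be only part of what the source reports. "The series", "measured", "known", "first", "only" and "open" are said of these compounds alone.

Measured so far in a physicochemical assay for solubility, measured as thermodynamic solubility, at pH 7.3; on this read-out higher numbers stand for higher solubility and lower numbers for lower solubility:
compound 1 `CC[C@@H]1C[C@]1(NC(=O)[C@@H]1C[C@@H](Oc2cc(-c3csc(NC(C)C)n3)nc3c(Cl)c(OC)ccc23)CN1C(=O)[C@@H](NC(=O)O[C@@H]1C[C@@H]2C[C@@H]2C1)C(C)(C)C)C(=O)O` gives 72000 nM
compound 2 `CC[C@@H]1C[C@]1(NC(=O)[C@@H]1C[C@@H](Oc2cc(-c3csc(NC(C)C)n3)nc3c(Cl)c(OC)ccc23)CN1C(=O)[C@@H](NC(=O)O[C@H]1C[C@@H]2[C@H](C1)C2(F)F)C(C)(C)C)C(=O)O` gives 57000 nM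

Going by the values given here, compound 2 and compound 1 stand within the scatter of each other; the only step recorded is a 1.3-fold lower number from compound 1 to compound 2 (0.10 log units; within the scatter), a swap at the oxygen on the carbamate side. Compound 3 `CC[C@@H]1C[C@]1(NC(=O)[C@@H]1C[C@@H](Oc2cc(-c3csc(NC(C)C)n3)nc3c(Cl)c(OC)ccc23)CN1C(=O)[C@@H](NC(=O)O[C@@H]1C[C@@H]2[C@H](C1)C2(F)F)C(C)(C)C)C(=O)O` keeps every atom and bond of compound 2: the two compounds have the same atoms and bonds and differ only in configuration as drawn: 1 of 8 stereo elements differ; a stereocentre at a saturated ring carbon is drawn r in compound 2 and s in compound 3. Among the compounds with values here, no measured pair turns on a stereocentre, so the one step available bears on this change only as a sign that this part of the molecule has so far left this assay unmoved. For compound 3 no shift beyond the scatter is expected, no change at the digits printed from compound 2 to compound 3 (within the scatter). Compound 3 is estimated at 57000 nM, range 25000 nM to 130000 nM.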

Compound 3, solubility: 9000 nM
The estimate for compound 3 lay 6.3-fold (0.80 log units) above the measured number; the whole stated range lies above it.
By their numbers in this assay, from the lowest: compound 3; then compounds 2 and 1 (each within the scatter of the next).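

In this assay, the group on the carbamate oxygen is no longer without effect: there is a 6.3-fold lower number from compound 2 to compound 3 (0.80 log units; beyond the scatter), from a single stereocentre at a saturated ring carbon, drawn r and then s. The swap of the group of 6 heavy atoms for the group of 8 heavy atoms therefore reads differently by configuration: drawn s, it gives an 8.0-fold lower number from compound 1 to compound 3 (0.90 log units; beyond the scatter), whereas drawn r it stayed within the scatter. The gap can be placed on that stereocentre alone because of this: the fact that compounds 2 and 3 differ only in the configuration as drawn

Still open, from the compounds shown here alone, is whether this stereocentre matters in a ring without fluorine, or whether an amine on the ring or a longer chain on this oxygen would respond in the same way.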